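The compounds below may be only part of what the source reports. "The series", "measured", "known", "first", "only" and "open" are said of these compounds alone.

Measured compounds:
compound 1 `Cc1ccc(S(=O)(=O)Oc2ccccc2/C=C(\C#N)C(=O)Nc2nnc(Cc3ccccc3)s2)cc1` 16%
compound 2 `N#C/C(=C\c1ccccc1OS(=O)(=O)c1ccc(Cl)cc1)C(=O)Nc1nnc(Cc2ccccc2)s1` 26%
compound 3 `Cc1ccc(S(=O)(=O)Oc2ccccc2/C=C(\C#N)C(=O)Nc2nnc(Cc3ccc(Cl)cc3)s2)cc1` 15%

In a functional assay on HL-60 cells (Homo sapiens) for inhibition, read by CCK-8 assay, with a stated time of 48 h, tested at 20 uM (on this read-out lower numbers stand for less inhibition of growth and higher numbers for more inhibition of growth at the one concentration tested), compound 2 gives 26%, while compound 1 gives 16%. The two differ by methyl in place of chloro on an aromatic carbon, and the step reads a number 10 percentage points lower from compound 2 to compound 1 (within the scatter). Compound 3 differs from compound 1 by a chloro in place of hydrogen on an aromatic carbon; in this assay compound 3 gives 15%, a step of a number 1 percentage points lower from compound 1 to compound 3 (within the scatter). The difference between the cores of compound 3 and compound 2 is not broken down here; their values simply stand apart.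

Compound 4 `Cc1ccc(Cc2nnc(NC(=O)/C(C#N)=C/c3ccccc3OS(=O)(=O)c3ccc(C)cc3)s2)cc1` has not been measured. It differs from compound 3 by methyl in place of chloro on an aromatic carbon. This is the same change as from compound 2 to compound 1, though here it sits on the 4-chlorobenzyl part rather than on the (4-chlorophenyl)sulfonyl part. The account expects a small step for compound 4, a number 3 percentage points lower from compound 3 to compound 4 (within the scatter), because a number 10 percentage points lower from compound 2 to compound 1 (within the scatter) stayed within the scatter. Compound 4 is therefore estimated at 12%, with a range from 2% to 25%.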

Compound 4, percent growth inhibition at one concentration: 17%
For compound 4 the middle estimate is 5 percentage points below the measured one; the range from low to high includes it.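

In this assay, methyl in place of chloro on the 4-chlorobenzyl part gives a number 2 percentage points higher from compound 3 to compound 4 (within the scatter), and methyl in place of hydrogen at that place gives a number 1 percentage points higher from compound 1 to compound 4 (within the scatter). Set beside the same exchange of chloro for methyl on the other core, the two steps do not differ: the same change on two cores in this assay, a number 10 percentage points lower (within the scatter) from compound 2 to compound 1 and a number 2 percentage points higher (within the scatter) from compound 3 to compound 4, 12 percentage points apart, within the scatter of two such steps. This shows that the exchange leaves no measurable trace of dependence on the core in this small set, but it does not show that the change carries over with a fixed size, as both steps lie within the scatter and a small real effect of either sign would go unseen.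

Going by these compounds, what a methoxy group, an amine or a carboxylic acid would give in place of the chloro or methyl on either aromatic ring stays open. Also open, on these data alone, is how these steps would read at a concentration other than the one tested.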